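Amide variation on the shared nitro-sulfone core: inactive pair

The source may report more compounds than this note shows. Statements on the series, on what has been measured and on what is new or still open speak of the compounds shown alone.

Compound 1 `CN(Cc1cccc(F)c1)C(=O)CCCNC(=O)c1ccc(S(C)(=O)=O)c([N+](=O)[O-])c1` and compound 2 `CS(=O)(=O)c1ccc(C(=O)NCCCC(=O)N2Cc3ccccc3C2)cc1[N+](=O)[O-]` share one core; compound 3 `CN(Cc1ccccc1F)C(=O)CCCNC(=O)c1ccc(S(C)(=O)=O)c([N+](=O)[O-])c1` is the unmeasured member of the set. In an assay on isolated protein for inhibition of thyroid hormone receptor alpha (Homo sapiens), read by fluorescence polarization (on this read-out lower numbers stand for stronger inhibition and higher numbers for weaker inhibition), compound 1 gives > 60000 nM, which is a limit of the assay and not a number. In this assay compound 2 gives > 60000 nM, likewise only a limit. The step that the two limits leave unreadable from compound 1 to compound 2 therefore cannot be read, since both measured values are the limit of > 60000 nM in this assay, at which 2 of the 2 values shown sit. The change to compound 3 is a group of 10 heavy atoms (8 carbon, 1 nitrogen, 1 fluorine; one six-membered aromatic ring of carbon only) in place of a group of 9 heavy atoms (8 carbon, 1 nitrogen; one five-membered non-aromatic ring with 1 hetero atom, one six-membered aromatic ring of carbon only), on a carbonyl carbon. Among the measured compounds shown here, only this one measured step bears on it, and its size is hidden by the two limits; compound 1, which also bears a fluorinated benzyl on that amide, reaches only the limit. No step beyond the scatter is therefore expected in this assay, and compound 3 is expected to sit again at the limit. The estimated step that the limit leaves unreadable from compound 2 to compound 3 is expected to be flat. Compound 3 is estimated at 100000 nM, with a range from 30000 nM to 400000 nM.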

Compound 3, half-maximal inhibitory concentration: > 60000 nM
Compound 3 gave a limit, no number (the forecaster's own chance of this, stated with the estimate: 85%); the middle value lies beyond the limit too.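

In this assay compound 3 gives > 60000 nM, a limit and not a number. No step among compound 1, compound 2 and compound 3 can be read: the limit of > 60000 nM in this assay, at which 3 of the 3 values shown sit.

The compounds shown leave open whether any change on this amide brings inhibition to a readable value.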